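The source may hold more compounds than are shown below. What is called first, only, known or untested is meant among the compounds shown, and "the series" means these compounds.

Measured compounds:
compound 1 `CC(C)S(=O)(=O)N(Cc1ccccc1-c1ccccc1)[C@H]1CCNC1` — 2700 nM
compound 2 `CC(C)C(=O)N(Cc1ccccc1C(C)C)[C@H]1CCNC1` — 3410 nM
compound 3 `CS(=O)(=O)N(Cc1ccccc1C(F)(F)F)[C@H]1CCNC1` — 2890 nM

The three measured compounds share a core in which an amine nitrogen links a saturated ring carbon and a saturated chain carbon. In an assay on HEK293 cells for inhibition of sodium-dependent dopamine transporter (Homo sapiens) (on this read-out higher numbers stand for weaker inhibition and lower numbers for stronger inhibition), compound 1 gives 2700 nM, the lowest of the three numbers, though its gap to compound 3 at 2890 nM and to compound 2 at 3410 nM both lie within the scatter of repeated measurements, so the three cannot be ordered on these numbers.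

Compound 4 `CN(C)C(=O)N(Cc1ccccc1-c1ccccc1)[C@H]1CCNC1` is the next member of the set. It differs from compound 1 in one place: dimethylcarbamoyl in place of isopropylsulfonyl on an amine nitrogen. For the measured compounds named here, no step between measured compounds that differ in one place is available, so the size of this change has to be judged from the set as a whole, in which a sulfonyl substituent on this nitrogen (compounds 1 and 3) and a carbonyl substituent (compound 2) give numbers that do not separate.

On that basis compound 4 is expected to stay close to compound 1, with a step of a 1.2-fold higher number from compound 1 to compound 4 (0.07 log units; within the scatter) that is estimated not to exceed the scatter in either direction. The estimate for compound 4 in this assay is 3200 nM, with a range from 1100 nM to 9500 nM.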

Compound 4, inhibition constant: 2970 nM
For compound 4 the middle estimate is 1.1-fold (0.03 log units) above the measured one, and the stated range covers the measured number.
By their numbers in this assay, from the lowest: compounds 1, 3, 4 and 2 (each within the scatter of the next).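

In this assay, for the compounds shown here, the exchange of isopropylsulfonyl for dimethylcarbamoyl on an amine nitrogen gives a 1.1-fold higher number from compound 1 to compound 4 (0.04 log units; within the scatter), and this is the first reading of a change at this position with the rest of the structure held fixed. Earlier, sulfonyl and carbonyl substituents could be set side by side only across compounds that also differed elsewhere, whereas this pair shows directly that a group with sulfur and two double bonds outside aromatic rings can give way to one with nitrogen, a single carbonyl and one heavy atom fewer, while the two numbers stay within the scatter of each other. Nothing given here accounts for this outcome.

On these data alone, it remains open whether a substituent of another kind on this nitrogen, such as a chain ending in an amine or in a carboxylic acid, or a plain hydrogen in place of the whole group, would separate from these numbers. As far as these compounds go, it also remains open whether the same exchange would read alike in a compound carrying trifluoromethyl, as compound 3 does, in place of the aryl group that compound 1 and compound 4 share.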